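Benzimidazolylmethylsulfanyl analogue of compound 1

This account rests on a few compounds, and the source may have more. Where it says the series, first, only, none or still open, it means among the compounds named here.

Among the measured compounds shown here, compound 1 `Cc1cc(Nc2cc(-c3ccccc3)[nH]n2)n2nc(SCc3ccc([N+](=O)[O-])cc3)nc2n1` gives 4250 nM in a functional assay on MGC-803 cells (Homo sapiens) for inhibition, read by MTT assay, with a stated time of 72 h (a higher number here means a weaker inhibitor, a lower number a stronger inhibitor), the highest of the three numbers so far, though compound 2 `Cc1cc(Nc2ccn(Cc3cccc4ccccc34)n2)n2nc(SCc3ccc(Br)cc3)nc2n1` at 3240 nM and compound 3 `Cc1cc(Nc2ccn(Cc3ccc(F)cc3)n2)n2nc(SCc3ccc(Br)cc3)nc2n1` at 3070 nM both lie within the scatter of it. Compound 4 `Cc1cc(Nc2cc(-c3ccccc3)[nH]n2)n2nc(SCc3nc4ccccc4[nH]3)nc2n1` differs from compound 1 by 1H-benzimidazol-2-yl in place of 4-nitrophenyl on a saturated chain carbon bound to a sulfur. For the measured compounds named here, the only measured step, a 1.1-fold lower number from compound 2 to compound 3 (0.02 log units; within the scatter), exchanges an aryl group on a saturated chain carbon bound to an aromatic nitrogen rather than on the saturated chain carbon bound to a sulfur, so it bears on the present change only loosely, showing an aryl exchange elsewhere leaving the number within the scatter. Going by the values given here, no measured step touches the sulfanyl-side group. With no movement beyond the scatter expected, compound 4 is estimated at 3600 nM (range 1400 nM to 9500 nM), an expected step of a 1.2-fold lower number from compound 1 to compound 4 (0.07 log units; within the scatter).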

Compound 4, half-maximal inhibitory concentration: 1790 nM
Compound 4: middle estimate off by 2.0-fold (0.30 log units), on the high side; the measured number falls inside the stated range.
By their numbers in this assay, from the lowest: compounds 4, 3, 2 and 1 (each within the scatter of the next, the first and the last beyond it).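

In this assay, among the compounds shown here, exchanging 4-nitrophenyl for 1H-benzimidazol-2-yl on a saturated chain carbon bound to a sulfur gives a 2.4-fold lower number from compound 1 to compound 4 (0.38 log units; beyond the scatter), the first step beyond the scatter, though a modest one. The group at this position can therefore shift the number, unlike the aryl exchange on the carbon bound to an aromatic nitrogen, which gave a 1.1-fold lower number from compound 2 to compound 3 (0.02 log units; within the scatter). No measured property accounts for this shift.

Open, as far as these compounds go, is whether an amine or a carboxylic acid on that same carbon would shift the number further. A longer chain between the sulfur and the 1H-benzimidazol-2-yl is equally untested among the compounds shown.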